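Methoxy for nitrile on the pendant aryl ring

This account rests on a few compounds, and the source may have more. Where it says the series, first, only, none or still open, it means among the compounds named here.

Measured so far:
compound 1, `CC(C)c1cc(C(C)(C)C)cc(-c2cccc(C#N)c2)c1CO`: > 50000 nM
compound 2, `COc1ccccc1-c1cc(C(C)(C)C)cc(C(C)C)c1CO`: 820 nM

In a functional assay on RKE cells for antagonist activity at Vasoactive intestinal polypeptide receptor 1 (Rattus norvegicus), read by HTRF and cAMP accumulation, with stated times of 10 min and 30 min (on this read-out lower numbers stand for stronger inhibition and higher numbers for weaker inhibition), compound 1 gives no number at all, only the limit of the assay, > 50000 nM. That reading is the one described as the limit of > 50000 nM in this assay, at which 1 of the 2 values shown sits, so compound 1 stands at the weak end of everything shown here, with no measured value to place it more exactly. Compound 2, which carries a methoxy group on its pendant aryl ring, gives 820 nM in this assay, a clear number rather than a limit.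

Compound 3, `COc1cccc(-c2cc(C(C)(C)C)cc(C(C)C)c2CO)c1`, has not yet been measured. It differs from compound 1 by methoxy in place of cyano on an aromatic carbon. Among the measured compounds shown here, because compound 1 shows only the limit > 50000 nM, no measured step between the two exists, and any gap can only be estimated. The step of an at least 10-fold lower number from compound 1 to compound 3 (1.00 log units; beyond the scatter) is expected to be large and toward stronger inhibition, beyond the scatter, though with real uncertainty about how far. Compound 3 is accordingly estimated at 5000 nM, with a range from 1000 nM to 40000 nM.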

Compound 3, half-maximal inhibitory concentration: 200 nM
For compound 3 the middle estimate is 25-fold (1.40 log units) above the measured one, and the stated range ends above it.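

Compound 3 shows that this position, on an aromatic carbon meta to a large group, responds strongly to the group it carries: methoxy in place of cyano gives an at least 250-fold lower number from compound 1 to compound 3 (2.39 log units; beyond the scatter). Compound 1 reads > 50000 nM, which is a limit of the assay and not a number, so the true size of this step stays unknown and only its lower bound can be read: the limit of > 50000 nM in this assay, at which 1 of the 3 values shown sits. The two groups match in heavy-atom count and in their counts of hydrogen-bond donors and acceptors, and no net charge enters or leaves, yet the read-out still separates them widely, so those counts alone do not account for the difference.

The compounds shown leave open whether this position would tolerate other groups, such as an amine, a carboxylic acid or a longer ether chain like ethoxy, in place of methoxy. They also leave open whether a hydroxyl at the same carbon would keep the inhibition seen with compound 3, or whether methoxy itself is needed.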